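Ethyl Carbamate Variant of a Methylated Diarylamine Melatonin Ligand

The source may report more compounds than this note shows. Statements on the series, on what has been measured and on what is new or still open speak of the compounds shown alone.

Measured so far:
Compound 1, `CCCC(=O)Nc1ccc(Oc2cccc(OC)c2)cc1`, 63 nM
Compound 2, `CCC(=O)Nc1ccc(Nc2cccc(OC)c2)cc1`, 61 nM
Compound 3, `CCC(=O)Nc1ccc(N(C)c2cccc(OC)c2)cc1`, 1 nM

In an assay on isolated protein for binding affinity to melatonin receptor type 1A (Homo sapiens) (a lower number here means a stronger inhibitor, a higher number a weaker inhibitor), compound 3 gives the lowest of the three numbers, with compound 2 nearest at a higher value and compound 1 furthest; both gaps stand beyond the scatter. Compounds 1 and 2 differ in two places at once, and their values in this assay sit close together, so nothing more is read from that pair. Going by the values given here, the one single-point step available, a 61-fold lower number from compound 2 to compound 3 (1.79 log units; beyond the scatter), concerns a methyl entering on a nitrogen on an aromatic ring and is large.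

Compound 4, `CCOC(=O)Nc1ccc(N(C)c2cccc(OC)c2)cc1`, differs from compound 3 at another place altogether: ethoxy in place of ethyl on a carbonyl carbon, that is, propanoyl to ethoxycarbonyl on the amide-type nitrogen. Among the compounds with values here, no measured step touches the carbonyl substituent, so the step from compound 2 to compound 3 does not bear on this change and gives no direction for it. The methylated nitrogen of compound 3 is kept in compound 4. With no comparison to lean on, compound 4 is expected to lose some ground against compound 3, an estimated step of a 5.0-fold higher number from compound 3 to compound 4 (0.70 log units; beyond the scatter). For compound 4 in this assay the estimated value is 5 nM, with an expected range from 1 nM to 25 nM.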

Compound 4, inhibition constant: 34 nM
Estimate against measurement, compound 4: 6.8-fold (0.83 log units) below; measured number above the stated range.
By their numbers in this assay, from the lowest: compound 3; then compounds 4, 2 and 1 (each within the scatter of the next).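

In this assay, going by these compounds alone, the carbonyl substituent on the amide-type nitrogen proves to be a sensitive place: with ethoxy in place of ethyl on a carbonyl carbon, there is a 34-fold higher number from compound 3 to compound 4 (1.53 log units; beyond the scatter), the first measured step at this position and a large one. The earlier compounds shown here showed only the gain of a 61-fold lower number from compound 2 to compound 3 (1.79 log units; beyond the scatter) with a methyl in place of hydrogen on a nitrogen on an aromatic ring. The new step shows that keeping this methyl does not by itself preserve the low number of compound 3, and nothing measured here bears on what lies behind the change.

The compounds shown leave open whether the step belongs to the oxygen itself or to the longer chain, a question that a butanoyl or a methoxycarbonyl group at the same place, on the same methylated core, would help to separate. Also open, as far as these compounds go, is whether propanoyl to ethoxycarbonyl gives a step of similar size when the nitrogen on the aromatic ring carries hydrogen rather than methyl, or whether the two changes depend on each other.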